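The compounds below may be only part of what the source reports. "The series", "measured", "known", "first", "only" and "open" are said of these compounds alone.

Measured compounds, cytotoxicity as half-maximal cytotoxic concentration:
compound 1 `Cc1cc(C)cc(S(=O)(=O)c2c(C(=O)NCN3CCCCC3)[nH]c3ccc(Br)cc23)c1`: 10000 nM
compound 2 `Cc1cc(C)cc(S(=O)(=O)c2c(C(=O)NCc3ccccc3)[nH]c3ccc([N+](=O)[O-])cc23)c1`: 8000 nM
compound 3 `Cc1cc(C)cc(S(=O)(=O)c2c(C(=O)NCCOc3ccccc3)[nH]c3ccc(Cl)c(F)c23)c1`: 11000 nM

All three were run in an ADME assay on CCRF-CEM cells (Homo sapiens) for cytotoxicity, read by cell counting; on this read-out lower numbers stand for higher toxicity in this test and higher numbers for lower toxicity in this test. Compound 2 has the smallest of the three numbers, yet compound 1 and compound 3 both sit within the scatter of it, so the series shows no separation. Compound 4 `Cc1cc(C)cc(S(=O)(=O)c2c(C(=O)NCN3CCCCC3)[nH]c3ccc([N+](=O)[O-])cc23)c1` is not yet measured. It differs from compound 2 by piperidin-1-yl in place of phenyl on a saturated chain carbon bound to an amide-type nitrogen. Compound 1 already carries the same ((piperidin-1-yl)methyl)carbamoyl group with a different substituent on the shared core, and its number matches compound 2 within the scatter. No step beyond the scatter is therefore expected from compound 2 to compound 4 in this assay, in either direction. Compound 4 is estimated at 9000 nM, range 4500 nM to 18000 nM, the expected step being a 1.1-fold higher number from compound 2 to compound 4 (0.05 log units; within the scatter).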

Compound 4, half-maximal cytotoxic concentration: 12000 nM
Beside the measured number, compound 4's estimate is 1.3-fold (0.12 log units) below it, and the stated range covers the measured number.
By their numbers in this assay, from the lowest: compounds 2, 1, 3 and 4 (each within the scatter of the next).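

In this assay the change from phenyl to piperidin-1-yl on a saturated chain carbon bound to an amide-type nitrogen gives a 1.5-fold higher number from compound 2 to compound 4 (0.18 log units; within the scatter) and so stays within the scatter, now read on a matched pair. Nitro in place of bromo on an aromatic carbon gives a 1.2-fold higher number from compound 1 to compound 4 (0.08 log units; within the scatter) and also stays within the scatter, so neither change separates these compounds. No measurement bearing on either step is available. Going by these compounds, whether a carboxylic acid or a morpholin-4-yl group at this chain carbon would give a step beyond the scatter remains open. The same holds for an amino group in place of nitro on the aromatic carbon.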